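Benzyl on the aromatic nitrogen of compound 1

The source may report more compounds than this note shows. Statements on the series, on what has been measured and on what is new or still open speak of the compounds shown alone.

Compound 1 `COc1ccc(-c2cc(=O)c3c(OC)cc(OC)cc3[nH]2)cc1`: > 62000 nM
Compound 2 `COc1ccc(-c2cc(=O)c3c(OC)cc(OC)cc3n2C)cc1`: 68000 nM

In an ADME assay on BJ cells (Homo sapiens) for antiproliferative activity, with a stated time of 72 h (on this read-out higher numbers stand for an effect only at larger amounts of compound and lower numbers for an effect already at smaller amounts), compound 1 is known only as a limit, > 62000 nM. Compound 3 `COc1ccc(-c2cc(=O)c3c(OC)cc(OC)cc3n2Cc2ccccc2)cc1` differs from it by benzyl in place of hydrogen on an aromatic nitrogen. For the measured compounds named here, the one measured step at this nitrogen is a step that the limit leaves unreadable from compound 1 to compound 2, so it gives neither a size nor a direction. Compound 2 still gives a number, 68000 nM, and on that basis no large change is expected in this assay from the larger benzyl group. The expected step is an at least 1.2-fold lower number from compound 1 to compound 3 (0.09 log units; that floor lies within the scatter). For compound 3 the estimated value is 50000 nM, with an expected range of 20000 nM to 100000 nM.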

Compound 3, half-maximal effective concentration: > 34400 nM
Compound 3: no number, only a limit; the forecaster's own chance of this, stated with the estimate: 35%; the middle value does not contradict the limit.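

Compound 3 gives only a limit, > 34400 nM, so the steps to it from compound 1 and from compound 2 cannot be read. The compounds shown leave open whether benzyl in place of hydrogen on the aromatic nitrogen shifts the value at all, and in which direction.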